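The compounds below may be only part of what the source reports. "The series", "measured", "known", "first", "only" and "open" are said of these compounds alone.

Of the compounds shown here, three sharing one core have been measured in a functional assay on BJAB cells (Homo sapiens) for antiproliferative activity, with a stated time of 4 days (on this read-out higher numbers stand for an effect only at larger amounts of compound and lower numbers for an effect already at smaller amounts), and a fourth awaits its number. Compound 1 `Cc1nn(-c2nc(-c3ccc(Cl)c(Cl)c3)c(SC(C)C)s2)c(C(=O)O)c1-c1cccc(F)c1` carries a 3-fluorophenyl group and gives 900 nM. Compound 2 `COc1cncc(-c2c(C)nn(-c3nc(-c4ccc(Cl)c(Cl)c4)c(SC(C)C)s3)c2C(=O)O)c1` carries a 5-methoxypyridin-3-yl group in the same place and gives 21000 nM. Compound 3 `COc1cc(C#N)cc(-c2c(C)nn(-c3nc(-c4ccc(Cl)c(Cl)c4)c(SC(C)C)s3)c2C(=O)O)c1` carries a 3-cyano-5-methoxyphenyl group and gives 5200 nM; it stands second highest of the three, closer to compound 2 than to compound 1, as the steps of a 4.0-fold lower number from compound 2 to compound 3 (0.61 log units; beyond the scatter) and a 5.8-fold higher number from compound 1 to compound 3 (0.76 log units; beyond the scatter) show.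

Compound 4 `Cc1nn(-c2nc(-c3ccc(Cl)c(Cl)c3)c(SC(C)C)s2)c(C(=O)O)c1-c1cccc(Cl)c1` differs from compound 3 in one place: 3-chlorophenyl in place of 3-cyano-5-methoxyphenyl on an aromatic carbon. For the measured compounds named here, the step that bears most directly on this is the one from compound 1 to compound 3, since compound 4 returns to a phenyl bearing a single halogen, as in compound 1, and a reversal of that step is expected, a fall of about a 5.2-fold lower number from compound 3 to compound 4 (0.72 log units; beyond the scatter). Compound 4 is therefore expected to give roughly 1000 nM in this assay, within a range from 400 nM to 3000 nM.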

Compound 4, half-maximal effective concentration: 13600 nM
Compound 4: middle estimate off by 14-fold (1.13 log units), on the low side, and the stated range ends below it.
By their numbers in this assay, from the lowest: compound 1; then compound 3; then compounds 4 and 2 (each within the scatter of the next).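

In this assay, exchanging only the halogen on the phenyl group is a large change: chloro in place of fluoro gives a 15-fold higher number from compound 1 to compound 4 (1.18 log units; beyond the scatter), so a single halogen on this ring does not by itself secure the low number of compound 1. The smaller 3-chlorophenyl group also fares worse than the larger 3-cyano-5-methoxyphenyl group, with a 2.6-fold higher number from compound 3 to compound 4 (0.42 log units; beyond the scatter), while a 1.5-fold lower number from compound 2 to compound 4 (0.19 log units; within the scatter) leaves 3-chlorophenyl and 5-methoxypyridin-3-yl indistinguishable, so group size alone does not order these compounds. Nothing available explains why fluoro and chloro part so widely here.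

Going by these compounds, it remains open how a plain phenyl group, or a phenyl carrying bromo or methyl in place of the halogen, would compare with compound 1. Also open, on these data alone, is whether a methoxy group added to the 3-fluorophenyl group would keep the low number of compound 1.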